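Swapping the 4-fluorophenyl group of compound 2

This account rests on a few compounds, and the source may have more. Where it says the series, first, only, none or still open, it means among the compounds named here.

In a functional assay on Jurkat cells (Homo sapiens) (on this read-out higher numbers stand for weaker inhibition and lower numbers for stronger inhibition), compound 2 `C[C@H](NC(=O)C(=O)NCc1ccc(F)cc1)C(=O)N[C@@H](CC(=O)O)C(=O)COc1c(F)c(F)cc(F)c1F` gives 197 nM, the higher of the two numbers measured, while compound 1 `C[C@H](NC(=O)C(=O)NCC1CCCCC1)C(=O)N[C@@H](CC(=O)O)C(=O)COc1c(F)c(F)cc(F)c1F` gives 19 nM. Compound 3 `Cc1ccc(CNC(=O)C(=O)N[C@@H](C)C(=O)N[C@@H](CC(=O)O)C(=O)COc2c(F)c(F)cc(F)c2F)cc1C` carries 3,4-dimethylphenyl in place of 4-fluorophenyl on a saturated chain carbon bound to an amide-type nitrogen. Within the data shown here, the only measured step, a 10-fold higher number from compound 1 to compound 2 (1.02 log units; beyond the scatter), is large, but it replaces cyclohexyl, whereas here one aromatic ring follows another. It bears only indirectly, so no step beyond the scatter is expected in this assay. The expected step is a 1.2-fold lower number from compound 2 to compound 3 (0.09 log units; within the scatter). Compound 3 is estimated at 160 nM, with an expected range of 50 nM to 500 nM.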

Compound 3, half-maximal inhibitory concentration: > 10000 nM
Compound 3 gave a limit, no number; the forecaster's own chance of this, stated with the estimate: 2%; at least 62-fold (1.79 log units) between middle value and limit.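

Compound 3 gives a limit rather than a number in this assay: the limit of > 10000 nM in this assay, at which 1 of the 3 values shown sits.

The earlier compounds shown here showed only cyclohexyl giving way to an aromatic ring, whereas here one aromatic ring replacing another is enough to produce an at least 50-fold higher number from compound 2 to compound 3 (1.70 log units; beyond the scatter). Exchanging cyclohexyl for 3,4-dimethylphenyl gives an at least 520-fold higher number from compound 1 to compound 3 (2.72 log units; beyond the scatter), so the choice of substituted ring at this place matters in this series of three compounds.

From the compounds shown here alone, it remains open how phenyl or 4-methylphenyl would read at this place. The compounds shown therefore cannot separate the loss of the fluorine from the entry of the two methyl groups.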